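This account rests on a few compounds, and the source may have more. Where it says the series, first, only, none or still open, it means among the compounds named here.

- compound 1 `CCCC(=O)N1c2ccccc2CCC1C(=O)Nc1ccccc1C(F)(F)F`: > 70000 nM
- compound 2 `CCCCCCCCC(=O)N1c2ccccc2CCC1C(=O)Nc1ccccc1C(F)(F)F`: 3350 nM
- compound 3 `O=C(Nc1ccccc1C(F)(F)F)C1CCc2ccccc2N1`: 45500 nM

In a functional assay on MDA-MB-231 cells (Homo sapiens) for cytotoxicity, read by sulforhodamine B assay, with a stated time of 72 h (on this read-out higher numbers stand for weaker inhibition of growth and lower numbers for stronger inhibition of growth), compound 3 gives 45500 nM, the higher of the two exact numbers, while compound 2 gives 3350 nM. Compound 1 gives > 70000 nM, which is a limit of the assay and not an exact number.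

Compound 4 `O=C(Nc1ccccc1C(F)(F)F)C1CCc2ccccc2N1C(=O)c1cccc(Cl)c1` differs from compound 3 in one place: (3-chlorophenyl)carbonyl in place of hydrogen on a nitrogen on an aromatic ring in a ring. It therefore has (3-chlorophenyl)carbonyl in place of hydrogen on the ring nitrogen.

Two measured steps remove a group from that same nitrogen. Losing octylcarbonyl gives a large step, a 14-fold higher number from compound 2 to compound 3 (1.13 log units; beyond the scatter). Losing propylcarbonyl gives an at least 1.5-fold lower number from compound 1 to compound 3 (0.18 log units; that floor lies within the scatter). Between the two chains themselves lies an at least 20-fold lower number from compound 1 to compound 2 (1.32 log units; beyond the scatter). A group on this nitrogen can thus matter greatly or hardly at all, depending on the group, and neither chain carries an aromatic ring.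

With wide uncertainty, a moderate move towards stronger inhibition of growth is therefore expected, and the estimated step is a 3.8-fold lower number from compound 3 to compound 4 (0.58 log units; beyond the scatter). In this assay, compound 4 is estimated at 12000 nM, with an expected range of 3000 nM to 60000 nM.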

Compound 4, concentration for 50% growth inhibition: 288 nM
Compound 4: the middle estimate sits 42-fold (1.62 log units) above what was measured; the whole stated range lies above it.
By their numbers in this assay, from the lowest: compound 4; then compound 2; then compound 3. At a limit, above all of these: compound 1.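

In this assay, putting (3-chlorophenyl)carbonyl on the ring nitrogen gives a 160-fold lower number from compound 3 to compound 4 (2.20 log units; beyond the scatter), so this position can take a group with an aromatic ring and gain far more than the earlier chains suggested. With the carbonyl kept in place, 3-chlorophenyl in place of octyl still gives a 12-fold lower number from compound 2 to compound 4 (1.07 log units; beyond the scatter), which shows that what the carbonyl carries matters, and that here a ring outdoes the longer of the two chains. Replacing propyl gives an at least 240-fold lower number from compound 1 to compound 4 (2.38 log units; beyond the scatter); this is only a floor, and the value of compound 1 is a limit of the assay: the limit of > 70000 nM in this assay, at which 1 of the 4 values shown sits.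

From the compounds shown here alone, whether the gain comes from the ring itself or from its chlorine stays open: a plain phenyl or a pyridine ring on the carbonyl would separate the two. What lies behind the gain also remains unknown.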